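The source may report more compounds than this note shows. Statements on the series, on what has been measured and on what is new or still open speak of the compounds shown alone.

Series notes. Compound 3 `CC[C@@H]1C(=O)N(C)c2cnc(-n3ccc4cc(C(=O)NC5CCCC5)ccc43)nc2N1C1CCCC1` gives 795 nM in a functional assay on MCF7 cells (Homo sapiens) for antiproliferative activity, read by CCK-8 assay, with a stated time of 72 h; a higher number here means a weaker inhibitor of growth, a lower number a stronger inhibitor of growth. Compound 2 `CCCCNC(=O)c1ccc2c(ccn2-c2ncc3c(n2)N(c2ccn(C)n2)C(CC)C(=O)N3C)c1` gives 8990 nM in this assay, a higher number than that of compound 3 and beyond the scatter of repeated measurements. Compound 1 `CCC1C(=O)N(C)c2cnc(-n3ccc4cc(C(N)=O)ccc43)nc2N1c1ccn(C)n1` is reported in this assay as "not active" (no number reported), with no number attached. Of the two numbers in hand, that of compound 3 is the lower.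

Compound 4 `CC[C@@H]1C(=O)N(C)c2cnc(-n3ccc4ccccc43)nc2N1C1CCCC1` has not yet been measured in this assay. It differs from compound 3 in one place: hydrogen in place of cyclopentylcarbamoyl on an aromatic carbon. Among the measured compounds shown here, no step between two measured compounds is available as a guide for this change; compound 1 and compound 2 differ from compound 3 in more than one place, so neither isolates it. Compound 4 is expected to be a weaker inhibitor of growth than compound 3 in this assay. For compound 4 the step is estimated as a 3.8-fold higher number from compound 3 to compound 4 (0.58 log units; beyond the scatter), a loss beyond the scatter but smaller than the gap between compound 3 and compound 2. The estimate for compound 4 in this assay is 3000 nM, with a range from 800 nM to 12000 nM.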

Compound 4, concentration for 50% growth inhibition: 17200 nM
For compound 4 the middle estimate is 5.7-fold (0.76 log units) below the measured one, and the stated range ends below it.
By their numbers in this assay, from the lowest: compound 3; then compounds 2 and 4 (each within the scatter of the next).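

Hydrogen in place of cyclopentylcarbamoyl on this aromatic carbon gives a 22-fold higher number from compound 3 to compound 4 (1.34 log units; beyond the scatter) in this assay, the only step in the series that isolates this position. The growth inhibition seen with compound 3 is thus tied to the substituent at this carbon, a link that compound 1 and compound 2 could not show because each differs from compound 3 in more than one place. No measurement at hand bears on the cause of this step.

It remains open which part of the cyclopentylcarbamoyl group carries the difference, as the compounds shown do not separate the five-membered ring of carbon only from the carbonyl and the amide hydrogen. Among the compounds shown here, also open is how a carboxylic acid, an unsubstituted carboxamide or an amide with an open butyl chain at this aromatic carbon would read out with everything else in compound 3 held fixed, so the single step gives a direction for this one change and no trend across substituents.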